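Swapping a methylsulfanyl for a triazolyl on the amide ring

A few compounds are considered here, and "the series" means these few. Any claim that something is new, unique, unknown or untested is made for them only; others in the source may bear on it.

Three compounds sharing a common core have been examined in a functional assay on cells for antagonist activity at Orexin/Hypocretin receptor type 1 (Homo sapiens), read by FLIPR and calcium flux; a higher number here means a weaker inhibitor, a lower number a stronger inhibitor. Compound 1, with the structure `CC(=O)Nc1cc(C(=O)N2C[C@H](Oc3nccc(C#N)c3C)CC[C@H]2C)c(-c2ccccc2)cn1`, gives 71 nM. Compound 2, with the structure `Cc1c(C#N)ccnc1O[C@@H]1CC[C@@H](C)N(C(=O)c2ccccc2-n2ncnn2)C1`, gives 4590 nM. Compound 3, with the structure `COc1ccc(C(=O)N2C[C@H](Oc3nccc(C#N)c3C)CC[C@H]2C)c(SC)n1`, gives only a limit in this assay, reported as > 10000 nM, so no exact number is known for it. This places compound 3 at the weak end of what has been seen so far, at the limit of > 10000 nM in this assay, at which 1 of the 3 values shown sits. Compound 1 sits far stronger, and compound 2 stands between the two, though the values of compounds 1 and 2 are both real numbers while that of compound 3 is not.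

Compound 4, with the structure `COc1ccc(C(=O)N2C[C@H](Oc3nccc(C#N)c3C)CC[C@H]2C)c(-n2nccn2)n1`, has not yet been measured in this assay. It differs from compound 3 in one place: 2H-1,2,3-triazol-2-yl in place of methylsulfanyl on an aromatic carbon.

Because compound 3 gives > 10000 nM, any measurable result for compound 4 would already mark a move toward stronger inhibition. Compound 4 is expected to show a step of an at least 12-fold lower number from compound 3 to compound 4 (1.09 log units; beyond the scatter) toward stronger inhibition, well beyond the usual scatter. The estimate for compound 4 in this assay is 800 nM, with a likely range from 150 nM to 5000 nM.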

Compound 4, half-maximal inhibitory concentration: 5930 nM
Estimate against measurement, compound 4: 7.4-fold (0.87 log units) below; measured number outside the range, above it.
By their numbers in this assay, from the lowest: compound 1; then compounds 2 and 4 (each within the scatter of the next). At a limit, above all of these: compound 3.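

With 2H-1,2,3-triazol-2-yl on this aromatic carbon, next to the ring nitrogen, compound 4 gives a measurable value of 5930 nM in this assay, which the earlier methylsulfanyl compound did not provide. The change can be stated only as an at least 1.6-fold lower number from compound 3 to compound 4 (0.22 log units; that floor lies within the scatter), and since that floor lies within the scatter, this pair does not establish a real gain, although the true step could be larger. The reading for compound 3 is a limit and not a number, which is why the step has only a floor: the limit of > 10000 nM in this assay, at which 1 of the 4 values shown sits.

The compounds shown leave open whether the five-membered aromatic ring itself matters at this place or whether another group would serve as well, such as a pyrazolyl ring, a dimethylamino group or a single chlorine atom. They also cannot show whether the same swap would give a similar result with something other than the methoxy group on the ring, for example an ethoxy group or a hydrogen atom in its place.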